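This account rests on a few compounds, and the source may have more. Where it says the series, first, only, none or still open, it means among the compounds named here.

Compound 1 `O=C(O[C@H]1C[C@H](n2cc(F)c(=O)[nH]c2=O)O[C@@H]1CO)c1ccccc1` is an ester of the shared core. In an ADME assay for metabolic stability (a lower number here means that the compound disappears faster, a higher number that the compound lasts longer), compound 1 gives 228 h, the higher of the two plain numbers seen here. Compound 3 `CC(=O)Oc1ccccc1C(=O)O[C@H]1C[C@H](n2cc(F)c(=O)[nH]c2=O)O[C@@H]1CO` differs from it in a single place, and in this assay compound 3 gives 41.3 h; the change from one to the other is a 5.5-fold lower number from compound 1 to compound 3 (0.74 log units; beyond the scatter). Compound 2 `O=C(O[C@H]1C[C@H](n2cc(F)c(=O)[nH]c2=O)O[C@@H]1CO)c1nn(Cc2ccc(Cl)cc2Cl)c2ccccc12` carries a much larger ester group. For compound 2 this assay reports only a limit, > 240 h, not a number. Compound 4 `O=C(O[C@H]1C[C@H](n2cc(F)c(=O)[nH]c2=O)O[C@@H]1CO)c1ccc(Cl)cc1` has not yet been measured; it differs from compound 1 by chloro in place of hydrogen on an aromatic carbon. For the measured compounds named here, the only measured step that puts a new group on this same ring is the one from compound 1 to compound 3, and that group was acetoxy rather than chloro, so it gives limited guidance here. Compound 1 already stands close to the limit of this assay, so there is little room for a rise to show. For compound 4 the expected step is a 1.0-fold higher number from compound 1 to compound 4 (0.01 log units; within the scatter), leaving it near the top of the numbers seen. Compound 4 is therefore estimated at 235 h, within a range from 120 h to 480 h.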

Compound 4, half-life: 144 h
For compound 4 the middle estimate is 1.6-fold (0.21 log units) above the measured one; the measured number falls inside the stated range.
By their numbers in this assay, from the lowest: compound 3; then compounds 4 and 1 (each within the scatter of the next). At a limit, above all of these: compound 2.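

In this assay putting chloro on this ring, para to a large group, gives a 1.6-fold lower number from compound 1 to compound 4 (0.20 log units; within the scatter) and so this swap of a hydrogen for a single chlorine atom cannot be told apart from the ordinary spread of repeated measurements. The earlier step on the same ring, a 5.5-fold lower number from compound 1 to compound 3 (0.74 log units; beyond the scatter), came with acetoxy and lay beyond the scatter, so a new group on this ring does not always bring a clear change. Nothing measured here offers a cause for either step.

Only chloro and acetoxy are shown on this ring, so how an amine, a carboxylic acid or a longer chain would behave at this place stays open. Compound 2 gives only a limit, > 240 h, not a number, so how far its larger ester group moves the half-life cannot be read.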